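A few compounds are considered here, and "the series" means these few. Any claim that something is new, unique, unknown or untested is made for them only; others in the source may bear on it.

Of the compounds shown here, two have been measured in a functional assay on MCF7 cells (Homo sapiens) for cytotoxicity, read by MTT assay, with a stated time of 48 h; on this read-out higher numbers stand for weaker inhibition and lower numbers for stronger inhibition. Compound 1 `COc1cc(CN(C(=O)Nc2ccc(C)cc2)n2cnnc2)cc(OC)c1OC` gives > 50000 nM. Compound 2 `O=C(NCc1ccccc1)N(Cc1ccccn1)n1cnnc1` gives > 50000 nM.

The value of compound 1 is a limit of the assay, not a number. The value of compound 2 is likewise a limit of the assay and not a number. Both readings sit at the limit of > 50000 nM in this assay, at which 2 of the 2 values shown sit, so neither compound can be placed above or below the other on this read-out, and compound 2 stands simply among compounds for which the assay did not return a number.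

Compound 3 `O=C(Nc1ccccc1)N(Cc1ccccn1)n1cnnc1` is the next compound to be measured. It differs from compound 2 in one place: phenyl in place of benzyl on an amide-type nitrogen. Within the data shown here, no step between two measured compounds is available here, so there is nothing to say about how a change of this kind has moved the read-out before.

With both measured compounds at the limit, the step from compound 2 to compound 3 in this assay is expected to be none beyond the usual scatter, and most likely compound 3 will again return only a limit. The estimate for compound 3 is 50000 nM, within a range of 15000 nM to 200000 nM, which means an expected step of a number no higher from compound 2 to compound 3 (the limit leaves the size open).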

Compound 3, half-maximal inhibitory concentration: > 50000 nM
Compound 3 ended at the assay's limit (the forecaster's own chance of this, stated with the estimate: 75%); the middle value sits exactly at the limit.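

No step can be read from compound 2 to compound 3 in this assay, because both readings are limits and not numbers: the limit of > 50000 nM in this assay, at which 3 of the 3 values shown sit.

The compounds shown leave open how phenyl and benzyl compare in this place, and what kind of structure, if any, would return an actual number in this assay.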